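The source may hold more compounds than are shown below. What is called first, only, known or untested is meant among the compounds shown, and "the series" means these compounds.

Measured so far:
- compound 1, `Cc1ccccc1-c1nn(-c2ccc(F)cc2F)cc1CN1CCN(c2ccccc2)CC1`: in an ADME assay on Huh-7 cells (Homo sapiens) for cytotoxicity (on this read-out higher numbers stand for lower toxicity in this test and lower numbers for higher toxicity in this test), compound 1 gives > 20000 nM, which is a limit of the assay and not a number.
- compound 2, `Cc1ccccc1-c1nn(-c2ccc(Cl)cc2)cc1CNCCN1CCN(C)CC1`: in this assay compound 2 gives 17000 nM.

For the measured compounds named here, compound 2 holds the only numerical value shown in this assay; the one other value is a limit, as told by the limit of > 20000 nM in this assay, at which 1 of the 2 values shown sits. Going by the values given here, no pair of measured compounds differs in a single place, so no measured step is available to set a scale for changes on the aromatic ring bearing the chloro group.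

Compound 3, `CSc1ccc(-n2cc(CNCCN3CCN(C)CC3)c(-c3ccccc3C)n2)cc1`, has not yet been measured in this assay. It differs from compound 2 as follows: methylsulfanyl in place of chloro on an aromatic carbon. Among the compounds with values here, nothing among the measured compounds shows how a methylsulfanyl in place of chloro on an aromatic carbon, para to a large group, bears on the half-maximal cytotoxic concentration. The expectation for compound 3 is therefore a step from compound 2 of no change at the digits printed from compound 2 to compound 3 (within the scatter), that is, none beyond the usual scatter. On that basis compound 3 is estimated at 17000 nM in this assay, with a range from 7000 nM to 40000 nM, and a fair chance that only a limit is reported.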

Compound 3, half-maximal cytotoxic concentration: 17000 nM
Estimate against measurement, compound 3: no gap at the digits printed; the range from low to high includes it.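

In this assay, methylsulfanyl in place of chloro on an aromatic carbon, para to a large group, gives no change at the digits printed from compound 2 to compound 3 (within the scatter). For the compounds shown here, this is the first measured step at this position, and it shows that the exchange of 4-chlorophenyl to 4-(methylsulfanyl)phenyl leaves the two values within the scatter of each other, with the rest of the structure held constant. The reading comes from near the top of the measurable range, so a step toward lower toxicity in this test would have little room to show and the flat result is weaker evidence on that side: the limit of > 20000 nM in this assay, at which 1 of the 3 values shown sits.

From the compounds shown here alone, whether a different group at this position, such as an amine or a carboxylic acid, would also stay within the scatter in this assay remains open, and a single exchange sets no trend for the position. Going by these compounds alone, the bearing of the side chain on the read-out is open as well, as compound 1 differs from compound 2 in more than one place and offers no single step to read.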